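The compounds below may be only part of what the source reports. "The series", "measured", "known", "first", "only" and "open" are said of these compounds alone.

Within the data shown here, in a functional assay on KB cells (Homo sapiens) for cytotoxicity, read by MTT assay, with a stated time of 72 h (a lower number here means a stronger inhibitor, a higher number a weaker inhibitor), compound 2 `O=C(CCc1ccc(O)c(O)c1)OCCCc1ccccc1` gives 125000 nM as the lower of the two numbers so far. Compound 1 `COc1ccc(CCCOC(=O)CCc2ccc(O)cc2)cc1` gives 820000 nM here, a gap beyond the scatter. Compound 3 `O=C(CCc1ccc(O)cc1)OCCCc1ccccc1` differs from compound 2 in one place, where the change is hydrogen in place of hydroxy on an aromatic carbon with hydrogen in place of hydroxy on an aromatic carbon. Among the measured compounds shown here, no measured pair shows this change alone. Compound 1 also lacks that hydroxy and gives 820000 nM despite differing elsewhere too, so a rise beyond the scatter is expected, though on thin evidence. The estimated change is a 3.6-fold higher number from compound 2 to compound 3 (0.56 log units; beyond the scatter) in size. For compound 3 the estimated value is 450000 nM with 180000 nM to 1000000 nM as its range.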

Compound 3, half-maximal inhibitory concentration: 129000 nM
Estimate against measurement, compound 3: 3.5-fold (0.54 log units) above; measured number outside the range, below it.
By their numbers in this assay, from the lowest: compounds 2 and 3 (each within the scatter of the next); then compound 1.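

In this assay, hydrogen and hydroxy at this place, ortho to a hydroxy group, give matching numbers, with a 1.0-fold higher number from compound 2 to compound 3 (0.01 log units; within the scatter), so this hydroxy does not separate the two compounds. The clear gap instead appears where hydrogen stands in place of methoxy on an aromatic carbon, with a 6.4-fold lower number from compound 1 to compound 3 (0.80 log units; beyond the scatter). Nothing measured here explains either result. Still open, on these data alone, is how an amine or a carboxylic acid at the hydroxy position would read, and whether the methoxy step would hold with a longer chain.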